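This account rests on a few compounds, and the source may have more. Where it says the series, first, only, none or still open, it means among the compounds named here.

Compound 1 `CN1C/C(=C\c2cccnc2)C(=O)/C(=C/c2ccccc2F)C1` gives 5420 nM in a functional assay on SMMC-7721 cells (Homo sapiens) for cytotoxicity, read by MTT assay, with a stated time of 24 h; on this read-out lower numbers stand for stronger inhibition and higher numbers for weaker inhibition.
Compound 2 `CN1C/C(=C\c2ccc(C(F)(F)F)cc2)C(=O)/C(=C/c2cccnc2)C1` gives 4830 nM in this assay.
Compound 3 `CN1C/C(=C\c2ccncc2)C(=O)/C(=C/c2ccccc2F)C1` gives 7000 nM in this assay.

All three values lie within the usual scatter of one another, so none of these compounds can be called more or less active than the others. Compound 4 `CN1C/C(=C\c2ccncc2)C(=O)/C(=C/c2ccc(C(F)(F)F)cc2)C1` has not yet been measured in this assay. It differs from compound 2 by one change, (pyridin-4-yl in place of pyridin-3-yl on a double-bonded chain carbon bound to a double-bonded ring carbon). The same change, (pyridin-4-yl in place of pyridin-3-yl on a double-bonded chain carbon bound to a double-bonded ring carbon), separates compound 1 from compound 3, where the step was a 1.3-fold higher number from compound 1 to compound 3 (0.11 log units; within the scatter). How the core of compound 2 differs from the core of compound 1 is not broken down here. For compound 4 a step of similar size, a 1.3-fold higher number from compound 2 to compound 4 (0.12 log units; within the scatter), is expected, because a 1.3-fold higher number from compound 1 to compound 3 (0.11 log units; within the scatter) stayed within the scatter. Compound 4 is therefore estimated to give 6300 nM in this assay, most likely between 3200 nM and 12500 nM.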

Compound 4, half-maximal inhibitory concentration: 17700 nM
Compound 4: the middle estimate sits 2.8-fold (0.45 log units) below what was measured; measured number outside the range, above it.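

Replacing pyridin-3-yl with pyridin-4-yl gives a 3.7-fold higher number from compound 2 to compound 4 (0.56 log units; beyond the scatter) in this assay, a real loss of activity on this core. Going by these compounds alone, the same change therefore does not carry over at the same size from one core to the other: the same change on two cores in this assay, a 1.3-fold higher number (0.11 log units; within the scatter) from compound 1 to compound 3 and a 3.7-fold higher number (0.56 log units; beyond the scatter) from compound 2 to compound 4, 2.8-fold (0.45 log units) apart, beyond the scatter of two such steps This rests on only two steps, so it shows that the core can alter the size of the step, but not which feature of the core is responsible or how the change would behave on a third core.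

As far as these compounds go, it also remains open how a ring bearing an amine or a carboxylic acid would read in this assay. Whether such a group would alter the step is equally unknown.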